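Working notes: compound 3, amine replacement at the thiocarbonyl carbon

A few compounds are considered here, and "the series" means these few. Any claim that something is new, unique, unknown or untested is made for them only; others in the source may bear on it.

Measured so far in a functional assay on HCT-116 cells (Homo sapiens) for inhibition, read by CCK-8 assay, with a stated time of 48 h; on this read-out higher numbers stand for weaker inhibition and lower numbers for stronger inhibition:
- compound 1 `CCN1CCN(C(=S)SCC(=O)N(Cc2ccc(OC)cc2)c2cc(OC)c(OC)c(OC)c2)CC1`: 7700 nM
- compound 2 `COc1ccc(CN(C(=O)CSC(=S)N2CCN(Cc3ccc(C(C)(C)C)cc3)CC2)c2cc(OC)c(OC)c(OC)c2)cc1`: 6890 nM

Compound 1 holds the highest of the two numbers in this assay; its nearest neighbour is compound 2, and the step of a 1.1-fold lower number from compound 1 to compound 2 (0.05 log units; within the scatter) is within the scatter, so the two values cannot be ordered. That step concerns 4-(tert-butyl)phenyl in place of methyl on a saturated chain carbon bound to an amine nitrogen in a ring, a change at the far end of the group attached to the thiocarbonyl carbon.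

Compound 3 `COc1ccc(CN(C(=O)CSC(=S)N2CCCC2)c2cc(OC)c(OC)c(OC)c2)cc1` has not yet been measured in this assay. Its difference from compound 1 is pyrrolidin-1-yl in place of 4-ethylpiperazin-1-yl on a thiocarbonyl carbon. Within the data shown here, no measured step changes this group itself; the only step in hand, a 1.1-fold lower number from compound 1 to compound 2 (0.05 log units; within the scatter), alters a substituent on that group and leaves the number unmoved. There is therefore no basis for expecting a step beyond the scatter in either direction.

Compound 3 is accordingly expected near the value of compound 1, with the estimated step of a 1.1-fold lower number from compound 1 to compound 3 (0.04 log units; within the scatter). The estimate for compound 3 in this assay is 7000 nM, with an expected range from 3000 nM to 18000 nM.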

Compound 3, half-maximal inhibitory concentration: 4970 nM
Beside the measured number, compound 3's estimate is 1.4-fold (0.15 log units) above it; the range from low to high includes it.
By their numbers in this assay, from the lowest: compounds 3, 2 and 1 (each within the scatter of the next).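

In this assay, among these compounds, the group on the thiocarbonyl carbon is now exchanged as a whole for the first time: pyrrolidin-1-yl in place of 4-ethylpiperazin-1-yl gives a 1.5-fold lower number from compound 1 to compound 3 (0.19 log units; within the scatter), so the two values cannot be ordered. Compound 2 had changed only a substituent on the piperazine, whereas compound 3 shows that a five-membered ring with 1 hetero atom, at 5 heavy atoms rather than 8, also leaves the number within the scatter, and with a 1.1-fold lower number from compound 1 to compound 2 (0.05 log units; within the scatter) neither change at this position has yet produced a readable difference. No measurement at hand explains why the number stays within the scatter across these exchanges.

Going by these compounds, it remains open whether any amine on the thiocarbonyl carbon can move the number beyond the scatter, for example morpholin-4-yl with its ring oxygen, or an open-chain diethylamino group. The compounds shown also say nothing about how much the shared core itself contributes, since a carbonyl in place of the thiocarbonyl or a change to the groups on the amide nitrogen would be needed to test that.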